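Does flipping one stereocentre change cytotoxicity?

The compounds below may be only part of what the source reports. "The series", "measured", "known", "first", "only" and "open" are said of these compounds alone.

Measured in a functional assay on Hep 3B2 cells (Homo sapiens) for cytotoxicity, read by MTT assay; on this read-out lower numbers stand for stronger inhibition and higher numbers for weaker inhibition:
- Compound 1 `CC1(C)CCc2c(C3CCc4ccc(O)cc4O3)ccc(O)c2O1`: 51000 nM
- Compound 2 `CC1(C)CCc2c([C@@H]3CCc4ccc(O)cc4O3)ccc(O)c2O1`: 44700 nM
- Compound 3 `CC1(C)C=Cc2c([C@H]3CCc4ccc(O)cc4O3)ccc(O)c2O1`: 63600 nM

Compound 2 sits within the usual scatter of both other compounds, so these values cannot be ranked. Compound 4 `CC1(C)CCc2c([C@H]3CCc4ccc(O)cc4O3)ccc(O)c2O1` has the same atoms and bonds as compound 2, and the change is the two compounds have the same atoms and bonds and differ only in configuration as drawn: 1 of 1 stereo elements differ; a stereocentre at a saturated ring carbon is drawn S in compound 2 and R in compound 4. Within the data shown here, the one measured step that bears on this is a 1.1-fold lower number from compound 1 to compound 2 (0.06 log units; within the scatter). It involves the same stereocentre, and what separates that pair is the fact that one of compounds 1 and 2 is drawn with a defined configuration and the other without, at the place where they differ. Among the measured compounds shown here, with only this small step as a guide, no change beyond the scatter is expected in this assay. The expected step is a 1.2-fold higher number from compound 2 to compound 4 (0.07 log units; within the scatter). For compound 4 the estimated value is 52000 nM, with an expected range of 30000 nM to 90000 nM.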

Compound 4, half-maximal inhibitory concentration: 41700 nM
Compound 4: the middle estimate sits 1.2-fold (0.10 log units) above what was measured; the measured number falls inside the stated range.
By their numbers in this assay, from the lowest: compounds 4, 2, 1 and 3 (each within the scatter of the next).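

In this assay, the two drawn configurations at this saturated ring carbon can now be compared directly, giving a 1.1-fold lower number from compound 2 to compound 4 (0.03 log units; within the scatter). The form drawn without a configuration gives the same picture, with a 1.2-fold lower number from compound 1 to compound 4 (0.09 log units; within the scatter). So the S and R forms cannot be told apart here, and this pair isolates a single change: the fact that compounds 2 and 4 differ only in the configuration as drawn.

Going by these compounds, whether an amine or a carboxylic acid on the shared core would move the number beyond the scatter remains open. So does whether configuration at this carbon would matter once such a group is present.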